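Chain trimming on the saturated carbon: compound 2 to compound 3

The source may hold more compounds than are shown below. What is called first, only, known or untested is meant among the compounds shown, and "the series" means these compounds.

Compound 1 `COCC(C(=O)N1CCN(c2cccc(C(F)(F)F)c2)CC1)N1C(=O)CCC1=O` carries a methoxy group on the saturated chain carbon; in a functional assay on the whole organism (strain Swiss) with Mus musculus as the target, with a stated time of 0.5 h (on this read-out higher numbers stand for an effect only at larger amounts of compound and lower numbers for an effect already at smaller amounts), compound 1 gives only a limit of the assay, > 120 mg/kg. Within the data shown here, compound 2 `CCC(C(=O)N1CCN(c2cccc(C(F)(F)F)c2)CC1)N1C(=O)CCC1=O` has methyl in that place, and in this assay compound 2 gives 78.6 mg/kg, the only definite number in the set so far. The step of an at least 1.5-fold lower number from compound 1 to compound 2 (0.18 log units; that floor lies within the scatter) rests on that limit of > 120 mg/kg in this assay, at which 1 of the 2 values shown sits, and so sets only a floor. Compound 3 `CC(C(=O)N1CCN(c2cccc(C(F)(F)F)c2)CC1)N1C(=O)CCC1=O` differs from compound 2 by hydrogen in place of methyl on a saturated chain carbon, two bonds along the chain from an amide-type nitrogen in a ring and a carbonyl carbon. Among the measured compounds shown here, no measured step covers this change, and the single step available is itself within the scatter. The step of a 1.0-fold higher number from compound 2 to compound 3 (0.01 log units; within the scatter) is therefore expected to stay within the scatter. Compound 3 is expected near 80 mg/kg, between 35 mg/kg and 180 mg/kg.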

Compound 3, dose for half-maximal effect: 59.9 mg/kg
Compound 3: the middle estimate sits 1.3-fold (0.13 log units) above what was measured; low and high end bracket the measured number.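

Hydrogen and methyl on this saturated chain carbon are not told apart in this assay, the first step here with definite numbers at both ends: a 1.3-fold lower number from compound 2 to compound 3 (0.12 log units; within the scatter). Against methoxy there is only a floor, an at least 2.0-fold lower number from compound 1 to compound 3 (0.30 log units; that floor lies within the scatter), which also stays within the scatter. That comparison cannot settle how methoxy ranks against hydrogen, because it rests on a limit: the limit of > 120 mg/kg in this assay, at which 1 of the 3 values shown sits.

From the compounds shown here alone, whether a longer chain, an amine or a carboxylic acid on this carbon would move the read-out beyond the scatter stays open. Going by these compounds, a definite number for compound 1 also remains open.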